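A few compounds are considered here, and "the series" means these few. Any claim that something is new, unique, unknown or untested is made for them only; others in the source may bear on it.

In an assay on LX2 cells for inhibition of COL1A1 promoter (Homo sapiens), read by a luciferase reporter, with a stated time of 24 h, tested at 20 uM (on this read-out lower numbers stand for a weaker effect and higher numbers for a stronger effect at the one concentration tested), compound 2 `CC[N+]1(CCCCCCCOc2cc(-n3cc(C(=O)Nc4cc(F)cc(F)c4)c(=O)c4ccc(N(C)C)nc43)ccc2C)CCCC1` gives 57%. That is the only figure in the set: compound 1 `CN(C)c1ccc2c(=O)c(C(=O)Nc3cc(F)cc(F)c3)cn(-c3ccc(Cl)c(OCCCCCCC[n+]4ccccc4)c3)c2n1` was returned as "not active" (no number reported) with no number attached, so compound 2 stands alone as the reference point and there is no ranking to place it in. Compound 3 `CC[N+]1(CCCCCCCOc2cc(-n3cc(C(=O)Nc4cc(F)cc(F)c4)c(=O)c4ccc(N(C)C)nc43)ccc2Cl)CCCC1` has not yet been measured. It differs from compound 2 by chloro in place of methyl on an aromatic carbon. Within the data shown here, no step between two measured compounds is available for this kind of change, so its size must be judged from the change alone. With the remainder of the molecule held constant, the account expects a shift no larger than the usual scatter, tending if anything slightly downward. Compound 3 is expected to give 50% in this assay, within a range from 30% to 70%. The expected step is a number 7 percentage points lower from compound 2 to compound 3 (within the scatter), which stays inside the usual scatter.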

Compound 3, a percentage reported as inhibition, at one concentration (the size of the read-out at that concentration, not a potency): 46%
Compound 3: the middle estimate sits 4 percentage points above what was measured, within the range that was stated.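

In this assay, chloro in place of methyl on this aromatic carbon, ortho to a large group and para to a large group, gives a number 11 percentage points lower from compound 2 to compound 3 (beyond the scatter), so the position is not indifferent to this exchange, though the effect is modest. Compound 1 and compound 3 carry the same chloro and differ only in the ring at the end of the chain; compound 3 gives 46%, whereas compound 1 gives "not active" (no number reported), so chloro at this place does not by itself remove the read-out. Nothing available here accounts for the size of this step.

The compounds shown leave open whether a fluoro, a methoxy or a plain hydrogen on this carbon would read like methyl or like chloro. On these data alone, each figure also belongs to a single concentration, so how the effects of compound 2 and compound 3 compare at other concentrations remains open.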